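The compounds below may be only part of what the source reports. "The series", "measured", "known", "first", "only" and "open" are said of these compounds alone.

Three analogues of one shared core have been examined in an ADME assay on L6 cells (Rattus norvegicus) for cytotoxicity, read by resazurin assay, with a stated time of 70 h; a higher number here means a weaker inhibitor, a lower number a stronger inhibitor. Compound 1 `c1ccc(OCCCOc2ccc(-c3cc4cc(C5=NCCN5)ccc4o3)cc2)cc1` gives 10300 nM, compound 2 `c1ccc(OCCCCOc2ccc(-c3cc4cc(C5=NCCN5)ccc4o3)cc2)cc1` gives 2900 nM, and compound 3 `N=C(N)c1ccc2oc(-c3ccc(OCCCCCCOc4ccccc4)cc3)cc2c1` gives 3300 nM. Within this set compound 3 holds the second highest of the three numbers: compound 2 lies nearest to it, within the scatter, and compound 1 lies furthest, beyond the scatter. For the measured compounds named here, the only single-point change measured so far is the chain extension a 3.6-fold lower number from compound 1 to compound 2 (0.55 log units; beyond the scatter). Compound 4 `c1ccc(OCCCCCCOc2ccc(-c3cc4cc(C5=NCCN5)ccc4o3)cc2)cc1` differs from compound 3 by a group of 5 heavy atoms (3 carbon, 2 nitrogen; one five-membered non-aromatic ring with 2 hetero atoms) in place of a group of 3 heavy atoms (1 carbon, 2 nitrogen; no ring), on an aromatic carbon. Going by the values given here, no measured pair isolates this exchange; compounds 1 and 2 already carry the entering group, while compound 3 carries the leaving group on the longer chain that compound 4 keeps. Because compound 2 gives 2900 nM with that same entering group on a shorter chain, the expected step for compound 4 is a 1.3-fold lower number from compound 3 to compound 4 (0.10 log units; within the scatter), not beyond the scatter. Compound 4 is therefore estimated at 2600 nM, within a range of 1000 nM to 7000 nM.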

Compound 4, half-maximal inhibitory concentration: 1500 nM
Beside the measured number, compound 4's estimate is 1.7-fold (0.24 log units) above it; low and high end bracket the measured number.
By their numbers in this assay, from the lowest: compounds 4, 2 and 3 (each within the scatter of the next, the first and the last beyond it); then compound 1.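

In this assay the exchange on the aromatic carbon can now be read directly: with the chain held constant, the ring-bearing group of 5 heavy atoms in place of the open group of 3 heavy atoms gives a 2.2-fold lower number from compound 3 to compound 4 (0.34 log units; beyond the scatter) as a modest step beyond the scatter. Along the chain, a 6.9-fold lower number from compound 1 to compound 4 (0.84 log units; beyond the scatter) lies beyond the scatter, whereas a 1.9-fold lower number from compound 2 to compound 4 (0.29 log units; within the scatter) stays within it, so the further extension beyond compound 2 gives no clear step of its own. Nothing available explains either result.

As far as these compounds go, whether the same exchange would give a similar step on the shorter chains of compound 1 and compound 2 remains open. Also open, from the compounds shown here alone, is what a longer chain than that of compound 4, or an amine on the same aromatic carbon, would give.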